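The source may hold more compounds than are shown below. What is called first, only, known or untested is meant among the compounds shown, and "the series" means these compounds.

Measured compounds in a functional assay on BJAB cells (Homo sapiens) for antiproliferative activity, with a stated time of 4 days; on this read-out higher numbers stand for an effect only at larger amounts of compound and lower numbers for an effect already at smaller amounts:
Compound 1 `Cc1nn(-c2nc(-c3ccc(Cl)c(Cl)c3)c(SC(C)C)s2)c(C(=O)O)c1-c1ccc(Cl)cc1` gives 2500 nM.
Compound 2 `Cc1cccc(-c2c(C)nn(-c3nc(-c4ccc(Cl)c(Cl)c4)c(SC(C)C)s3)c2C(=O)O)c1` gives 17000 nM.
Compound 3 `Cc1nn(-c2nc(-c3ccc(Cl)c(Cl)c3)c(SC(C)C)s2)c(C(=O)O)c1-c1ccncc1` gives 5900 nM.

Compound 3 stands second highest of the three numbers in this assay: it is separated from compound 1 by a 2.4-fold higher number from compound 1 to compound 3 (0.37 log units; beyond the scatter) and from compound 2 by a 2.9-fold lower number from compound 2 to compound 3 (0.46 log units; beyond the scatter), both beyond the scatter. Compound 4 `COc1cc(Cl)cc(-c2c(C)nn(-c3nc(-c4ccc(Cl)c(Cl)c4)c(SC(C)C)s3)c2C(=O)O)c1` has not been measured; it differs from compound 3 by 3-chloro-5-methoxyphenyl in place of pyridin-4-yl on an aromatic carbon.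

Both measured steps concern the same place on the shared core and thus bear directly on this change. Among the measured aryl groups, 4-chlorophenyl in compound 1 gives the lowest number, 3-methylphenyl in compound 2 the highest, and pyridin-4-yl in compound 3 sits between them. The incoming 3-chloro-5-methoxyphenyl, like the two phenyl variants, is a ring of carbon only, and it carries a chlorine as 4-chlorophenyl does and a second substituent as neither does. With one phenyl variant below and one above compound 3, a step of modest size is expected, more likely upward toward the range of compound 2 than downward, though the direction is uncertain. For compound 4 the expected step is a 1.4-fold higher number from compound 3 to compound 4 (0.13 log units; within the scatter), giving an estimate of 8000 nM, with a range from 2500 nM to 25000 nM.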

Compound 4, half-maximal effective concentration: 760 nM
The estimate for compound 4 lay 11-fold (1.02 log units) above the measured number; the whole stated range lies above it.
By their numbers in this assay, from the lowest: compound 4; then compound 1; then compound 3; then compound 2.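

In this assay, 3-chloro-5-methoxyphenyl on this aromatic carbon gives the lowest number of the four compounds, with a 7.8-fold lower number from compound 3 to compound 4 (0.89 log units; beyond the scatter), a 3.3-fold lower number from compound 1 to compound 4 (0.52 log units; beyond the scatter) and a 22-fold lower number from compound 2 to compound 4 (1.35 log units; beyond the scatter). The number set by 4-chlorophenyl is therefore not the lower end for this position, and a ring of carbon only does not fix the outcome: such rings now sit at both ends of the series, with 3-methylphenyl at the top, 3-chloro-5-methoxyphenyl at the bottom, and pyridin-4-yl, the only ring with a hetero atom, in the middle. No measurement on these compounds accounts for the drop in the number with this group.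

From the compounds shown here alone, it remains open whether the chlorine, the methoxy group or the two together carry the step, and 3-chlorophenyl and 3-methoxyphenyl would separate these contributions. Also open, going by these compounds, is how the number in this assay responds when an ethoxy group or an amine takes the place of the methoxy group on this ring.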